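Phenyl in place of isobutyl: compound 1 to compound 3

The source may hold more compounds than are shown below. What is called first, only, known or untested is meant among the compounds shown, and "the series" means these compounds.

Measured compounds:
compound 1 `CC(C)COC(=O)Nc1ccc([Se]C#N)cc1`: 9300 nM
compound 2 `O=C(Nc1ccc([Se][Se]c2ccc(NC(=O)Oc3ccc(F)cc3)cc2)cc1)Oc1ccc(F)cc1`: 8700 nM

Of the compounds shown here, two have been measured in a functional assay on CCRF-CEM cells (Homo sapiens) for cytotoxicity, read by MTT assay, with a stated time of 72 h; a higher number here means a weaker inhibitor of growth, a lower number a stronger inhibitor of growth. Compound 1 `CC(C)COC(=O)Nc1ccc([Se]C#N)cc1` gives 9300 nM, and compound 2 `O=C(Nc1ccc([Se][Se]c2ccc(NC(=O)Oc3ccc(F)cc3)cc2)cc1)Oc1ccc(F)cc1` gives 8700 nM. Compound 1 holds the higher of the two numbers, but its nearest neighbour, compound 2, lies within the scatter of it, so the two values show no difference that can be read as real.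

Compound 3 `N#C[Se]c1ccc(NC(=O)Oc2ccccc2)cc1` has not yet been measured. It differs from compound 1 in one place: phenyl in place of isobutyl on an oxygen next to a carbonyl group. Within the data shown here, no pair of measured compounds differs by this change, so no step of this kind is known from the data. What can be said is that compound 2 also carries a six-membered aromatic ring on an oxygen next to a carbonyl group, and its value sits within the scatter of compound 1. On that basis no step beyond the scatter is expected in this assay from this change, in either direction.

Compound 3 is therefore estimated to give 8000 nM in this assay, with a range from 3000 nM to 20000 nM. This corresponds to an expected step of a 1.2-fold lower number from compound 1 to compound 3 (0.07 log units; within the scatter).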

Compound 3, concentration for 50% growth inhibition: 22900 nM
Compound 3: the middle estimate sits 2.9-fold (0.46 log units) below what was measured, and the stated range ends below it.
By their numbers in this assay, from the lowest: compounds 2 and 1 (each within the scatter of the next); then compound 3.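

In this assay, among these compounds, phenyl in place of isobutyl on an oxygen next to a carbonyl group gives a 2.5-fold higher number from compound 1 to compound 3 (0.39 log units; beyond the scatter), the first step at this position that can be read, and a modest one. It shows that the number in this assay is not indifferent to the group at this position: of the two groups compared here, isobutyl goes with the stronger inhibition of growth and phenyl with the weaker. Nothing at hand accounts for the direction or the size of this step.

The one step does not separate the presence of a ring from the larger count of carbon atoms, so the compounds shown leave open which of the two differences matters, and whether a benzyl group or a longer chain at this position would fall nearer to isobutyl or to phenyl. They also leave open whether the same change would give a step of similar size on the core of compound 2.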